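The compounds below may be only part of what the source reports. "The series", "measured", "known", "first", "only" and "open" are said of these compounds alone.

Three compounds with a shared core have numbers in a functional assay on DU-145 cells (Homo sapiens) for inhibition, read by trypan blue exclusion, with a stated time of 72 h; on this read-out higher numbers stand for weaker inhibition and lower numbers for stronger inhibition. Compound 1 (`Cn1c(=O)c(S(=O)(=O)Cc2ccc(F)cc2F)cc2cnc(Nc3ccc4[nH]ccc4c3)nc21`) gives 1000 nM, compound 2 (`Cn1c(=O)c(S(=O)(=O)Cc2ccc(F)cc2)cc2cnc(Nc3ccc4[nH]ccc4c3)nc21`) gives 30000 nM, and compound 3 (`Cn1c(=O)c(C(=O)Nc2ccc(F)cc2)cc2cnc(Nc3ccc4[nH]ccc4c3)nc21`) gives 5000 nM. Compound 3 therefore holds the second highest of the three numbers, with weaker inhibition than compound 1 and stronger inhibition than compound 2.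

The next structure is compound 4 (`Cn1c(=O)c(S(=O)(=O)c2ccc(F)cc2)cc2cnc(Nc3ccc4[nH]ccc4c3)nc21`), which differs from compound 3 in one group: (4-fluorophenyl)sulfonyl in place of (4-fluorophenyl)carbamoyl on an aromatic carbon. Here, (4-fluorophenyl)sulfonyl takes the place of (4-fluorophenyl)carbamoyl on an aromatic carbon.

For the measured compounds named here, two measured steps bear on this change. The nearest is the modest 6.0-fold lower number from compound 2 to compound 3 (0.78 log units; beyond the scatter), which also exchanged a sulfonyl group for a carbamoyl group, but with (4-fluorobenzyl)sulfonyl rather than the group in compound 4. The other is the large 30-fold higher number from compound 1 to compound 2 (1.48 log units; beyond the scatter), where hydrogen replaced fluoro on an aromatic carbon. It shows that these two sulfonyl compounds lie far apart. Going by the values given here, no measured compound carries the (4-fluorophenyl)sulfonyl group itself, so neither direction is favoured, and no shift beyond the scatter is expected, though the uncertainty is wide.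

The expected step is a 1.2-fold higher number from compound 3 to compound 4 (0.08 log units; within the scatter). Compound 4 is estimated at 6000 nM, with an expected range from 1200 nM to 30000 nM.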

Compound 4, half-maximal inhibitory concentration: 300 nM
Estimate against measurement, compound 4: 20-fold (1.30 log units) above; measured number outside the range, below it.
By their numbers in this assay, from the lowest: compound 4; then compound 1; then compound 3; then compound 2.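

In this assay, the sulfonyl link at this position is not a poor choice in itself: (4-fluorophenyl)sulfonyl in place of (4-fluorophenyl)carbamoyl gives a 17-fold lower number from compound 3 to compound 4 (1.22 log units; beyond the scatter). The group carried on the sulfonyl sulfur matters a great deal, since 4-fluorophenyl in place of 4-fluorobenzyl gives a 100-fold lower number from compound 2 to compound 4 (2.00 log units; beyond the scatter), and 4-fluorophenyl in place of 2,4-difluorobenzyl still gives a 3.3-fold lower number from compound 1 to compound 4 (0.52 log units; beyond the scatter). The earlier advantage of the carbamoyl compound over a sulfonyl compound therefore holds only against the 4-fluorobenzyl group; with 4-fluorophenyl on the sulfur, the order of the two links is reversed.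

From the compounds shown here alone, it remains open whether other groups on the sulfonyl sulfur, such as a 2,4-difluorophenyl ring, a plain phenyl ring, a small methyl group or a chain ending in an amine, would match or improve on the 4-fluorophenyl group. Nothing measured here explains why the 4-fluorophenyl group on the sulfur gives a lower number than either benzyl group or why the sulfonyl link outdoes the carbamoyl link.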